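This account rests on a few compounds, and the source may have more. Where it says the series, first, only, none or still open, it means among the compounds named here.

Compound 2 `CO[C@H]1C=C(COC(C)=O)C(=O)[C@@H]2O[C@@](C)(OC)[C@](C)(OC)O[C@@H]12` has no number in an assay on isolated protein for inhibition of glutathione S-transferase A2 (Homo sapiens), read by spectrophotometry, with a stated time of 3 min; a higher number here means a weaker inhibitor, a lower number a stronger inhibitor: for compound 2 the outcome is recorded as "not determined" (no result reported). Its relatives mark out the scale: compound 1 `CCCCCCCCCCO[C@H]1C=C(COC(C)=O)C(=O)[C@@H]2O[C@@](C)(OC)[C@](C)(OC)O[C@@H]12` gives 33100 nM, and compound 3 `CO[C@]1(C)O[C@H]2[C@@H](OC/C=C/c3ccccc3)C=C(COC(C)=O)C(=O)[C@@H]2O[C@@]1(C)OC` gives 94200 nM; the measured step of a 2.8-fold higher number from compound 1 to compound 3 (0.45 log units; beyond the scatter) follows an exchange of one chain for another, not a change of configuration. Compound 4 `CO[C@@H]1C=C(COC(C)=O)C(=O)[C@@H]2O[C@@](C)(OC)[C@](C)(OC)O[C@@H]12` differs from compound 2 only in configuration: the two compounds have the same atoms and bonds and differ only in configuration as drawn: 1 of 5 stereo elements differ; a stereocentre at a saturated ring carbon is drawn S in compound 2 and R in compound 4. No measured step involves such a change, so nothing shown sets a size or direction for it in this assay. A weak result is expected because compound 1 gives 33100 nM and compound 3 gives 94200 nM. Compound 4 is estimated at 50000 nM, with a range from 15000 nM to 200000 nM.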

Compound 4, half-maximal inhibitory concentration: > 100000 nM
Compound 4: a limit, no number (the forecaster's own chance of this, stated with the estimate: 25%); middle value at least 2.0-fold (0.30 log units) from the limit.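

Compound 4 gives > 100000 nM in this assay, which is a limit and not a number. Among the compounds shown here, compound 2 has no number either, so no step from compound 2 to compound 4 can be read. On these data alone, what inverting this one ring carbon does to inhibition stays open.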